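One Substituent Swap Seen on Two Chain-End Rings

The compounds below may be only part of what the source reports. "The series", "measured", "known", "first", "only" and "open" are said of these compounds alone.

Compound 1 `COc1cc2ncnc(Nc3cccc(C(F)(F)F)c3)c2cc1OCCCN1CCNCCNCCNCC1` gives 15700 nM in a functional assay on A549 cells (Homo sapiens) for antiproliferative activity, read by MTT assay, with a stated time of 72 h; on this read-out higher numbers stand for weaker inhibition and lower numbers for stronger inhibition.
Compound 2 `COc1cc2ncnc(Nc3cccc(Cl)c3)c2cc1OCCCN1CCNCCNCCNCC1` gives 27100 nM in this assay.
Compound 3 `COc1cc2ncnc(Nc3cccc(C(F)(F)F)c3)c2cc1OCCCN1CCNCCNCC1` gives 37300 nM in this assay.

Compound 1 and compound 2 share one core, and the difference between them is chloro in place of trifluoromethyl on an aromatic carbon. The step that this change made is a 1.7-fold higher number from compound 1 to compound 2 (0.24 log units; within the scatter). Compound 3 carries a different core, and how the two cores differ is counted here: a group of 9 heavy atoms (6 carbon, 3 nitrogen; one nine-membered non-aromatic ring with 3 hetero atoms) in place of a group of 12 heavy atoms (8 carbon, 4 nitrogen; one twelve-membered non-aromatic ring with 4 hetero atoms), on a saturated chain carbon, three bonds along the chain from an oxygen on an aromatic ring. That change gave the step of a 2.4-fold higher number from compound 1 to compound 3 (0.38 log units; beyond the scatter). The values of compound 2 and compound 3 lie within the scatter of each other.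

Compound 4 `COc1cc2ncnc(Nc3cccc(Cl)c3)c2cc1OCCCN1CCNCCNCC1` has not been measured. It differs from compound 3 by chloro in place of trifluoromethyl on an aromatic carbon, the same change as from compound 1 to compound 2, and the place of the change is described in the same words for both pairs. In this assay the expected step is a 1.6-fold higher number from compound 3 to compound 4 (0.21 log units; within the scatter), which rests on the step of a 1.7-fold higher number from compound 1 to compound 2 (0.24 log units; within the scatter) seen for the same change on the other core. On that basis compound 4 is estimated at 60000 nM, expected to fall between 30000 nM and 120000 nM.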

Compound 4, half-maximal inhibitory concentration: > 50000 nM
Compound 4: only a limit was reported; the forecaster's own chance of this, stated with the estimate: 15%; the middle value does not contradict the limit.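

Compound 4 gives > 50000 nM in this assay, and this is a limit of the assay, not a number. Chloro in place of trifluoromethyl on the core of compound 3 therefore gives only a floor, an at least 1.3-fold higher number from compound 3 to compound 4 (0.12 log units; that floor lies within the scatter), so nothing here goes against carrying the change across, but agreement in size is not shown either: the same change on two cores in this assay, a 1.7-fold higher number (0.24 log units; within the scatter) from compound 1 to compound 2 and an at least 1.3-fold higher number (0.12 log units; that floor lies within the scatter) from compound 3 to compound 4; the limit leaves it open whether they differ The change to the smaller chain-end ring, with chloro kept in place, likewise gives only a floor, an at least 1.8-fold higher number from compound 2 to compound 4 (0.26 log units; that floor lies within the scatter), and it too cannot be sized against its earlier step: the same change on two cores in this assay, a 2.4-fold higher number (0.38 log units; beyond the scatter) from compound 1 to compound 3 and an at least 1.8-fold higher number (0.26 log units; that floor lies within the scatter) from compound 2 to compound 4; the limit leaves it open whether they differ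

Only two substituents on two chain-end rings are shown, so it stays open how a third ring would respond to this swap, or whether bromo or a nitrile at the same place would read like chloro or like trifluoromethyl. Going by these compounds, a longer chain carrying these rings is also open, and so is the actual value of compound 4.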